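From Amino to Dimethylamino: Compound 4 in Prospect

The source may report more compounds than this note shows. Statements on the series, on what has been measured and on what is new or still open speak of the compounds shown alone.

Three compounds set the scene for this account, each with an entry in a functional assay on HCT-116 cells (Homo sapiens) for cytotoxicity, read by MTT assay, with a stated time of 72 h; a higher number here means a weaker inhibitor, a lower number a stronger inhibitor. For compound 1 `O=C(NCc1ccc(F)cc1)c1nc(NCCO)c2cccnc2c1O`, the entry reads "not determined" (no result reported). Compound 2 `N[C@H]1CC[C@H](Nc2c(C(=O)NCc3ccco3)nc(Br)c3cccnc23)CC1` gives only a limit of the assay, > 10000 nM. Compound 3 `NCCCNc1c(C(=O)NCc2ccc(F)cc2)nc(Br)c2cccnc12` also gives only a limit, > 20000 nM. Compound 3 therefore has no exact value, and neither of the other two entries supplies one for comparison.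

Compound 4 `CN(C)CCCNc1c(C(=O)NCc2ccc(F)cc2)nc(Br)c2cccnc12` differs from compound 3 in one place: dimethylamino in place of amino on a saturated chain carbon, three bonds along the chain from a nitrogen on an aromatic ring. In words, this is dimethylamino in place of amino on a saturated chain carbon, three bonds along the chain from a nitrogen on an aromatic ring. For the measured compounds named here, no measured pair here shows what this change does in this assay, so the expectation rests on compound 3 and its limit of > 20000 nM. No step beyond the scatter is expected in either direction, and the estimated step of a number no higher from compound 3 to compound 4 (the limit leaves the size open) reflects that. Compound 4 is estimated at 20000 nM, with an expected range of 6000 nM to 60000 nM. The assay may also report only a limit for it, leaving its exact position open.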

Compound 4, half-maximal inhibitory concentration: > 10000 nM
Compound 4: no number, only a limit (the forecaster's own chance of this, stated with the estimate: 60%); the middle value is on the limit's open side.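

For the compounds shown here, compound 3 and compound 4 each carry only a limit of the assay in this assay, and no step between them can be read. The compounds shown leave open whether going from 3-aminopropyl to 3-(dimethylamino)propyl changes the result in this assay at all, and where the exact value of either compound lies.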